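The compounds below may be only part of what the source reports. "The series", "measured", "known", "first", "only" and "open" are said of these compounds alone.

Measured compounds:
- Compound 1, `C1=C(c2cccnc2)C[C@H]2CNC[C@@H]1C2`, gives 4 nM in an in vitro assay on SH-SY5Y cells for displacement of a labelled ligand from Neuronal acetylcholine receptor; alpha3/beta4 (Homo sapiens); on this read-out lower numbers stand for stronger inhibition and higher numbers for weaker inhibition.
- Compound 2, `COc1ccccc1Oc1cncc(C2=CC3CNCC(C2)C3)c1`, gives 56 nM in this assay.
- Compound 3, `C1=C(c2ccncc2)CC2CNCC1C2`, gives 459 nM in this assay.

Among these three, compound 2 has the second highest number: compound 3 sits above it by a gap beyond the scatter, and compound 1 sits below it by a gap that is also beyond the scatter, so compound 2 stands in the middle of the measured range.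

Compound 4, `COc1cncc(C2=CC3CNCC(C2)C3)c1`, has not yet been measured. It differs from compound 2 in a single place:

methyl in place of 2-methoxyphenyl on an oxygen on an aromatic ring

Compound 4 keeps the core shared with compound 1 and compound 2 but carries only a methyl on that oxygen. Because compound 1, with nothing on the aromatic ring at all, gives 4 nM, compound 4 is expected to move toward that lower number, a step down of moderate size, a 4.7-fold lower number from compound 2 to compound 4 (0.67 log units; beyond the scatter), beyond the scatter. The estimate for compound 4 is 12 nM, within a range from 3 nM to 45 nM.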

Compound 4, inhibition constant: 14.3 nM
For compound 4 the middle estimate is 1.2-fold (0.08 log units) below the measured one; measured number inside the range.
By their numbers in this assay, from the lowest: compound 1; then compound 4; then compound 2; then compound 3.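

In this assay, going by these compounds alone, the swap of 2-methoxyphenyl for methyl on this oxygen gives a 3.9-fold lower number from compound 2 to compound 4 (0.59 log units; beyond the scatter) and is the first comparison here in which only one place changes. It shows that the group on this oxygen matters to the number, and that the oxygen can carry far fewer heavy atoms, with no six-membered aromatic ring of carbon, without the number rising. On this one pair, the smaller group gives the lower number. Nothing measured here accounts for the direction of this step. The compounds shown leave open how an ethyl, a plain phenyl or a hydroxyl on the aromatic ring would compare. Such groups could help separate the part played by the carbon ring from that of the methoxy it carries.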